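Swapping the fluorophenyl for a dichlorophenyl on the pyrazoline core

A few compounds are considered here, and "the series" means these few. Any claim that something is new, unique, unknown or untested is made for them only; others in the source may bear on it.

Of the compounds shown here, three built on one shared core have been measured in an assay on cells for inhibition of histone deacetylase 4 (Homo sapiens), read by fluorescence, with a stated time of 30 min; on this read-out higher numbers stand for weaker inhibition and lower numbers for stronger inhibition. Compound 1 `O=C1NC(=O)/C(=C\c2ccc(OCC(=O)N3N=C(c4ccccc4)CC3c3ccc(C(F)(F)F)cc3)cc2)S1` gives 1000 nM. Compound 2 `O=C1NC(=O)/C(=C\c2ccc(OCC(=O)N3N=C(c4ccccc4)CC3c3ccc(F)cc3)cc2)S1` gives 1700 nM. Compound 3 `O=C1NC(=O)/C(=C\c2ccc(OCC(=O)N3N=C(c4ccccc4)CC3c3ccc(F)cc3F)cc2)S1` gives 2200 nM. Compound 2 thus sits between the other two: the step of a 1.7-fold higher number from compound 1 to compound 2 (0.23 log units; within the scatter) and the step of a 1.3-fold higher number from compound 2 to compound 3 (0.11 log units; within the scatter) both stay inside the usual spread of repeat measurements, so the three numbers cannot be ranked with confidence.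

The new compound 4 `O=C1NC(=O)/C(=C\c2ccc(OCC(=O)N3N=C(c4ccccc4)CC3c3ccc(Cl)c(Cl)c3)cc2)S1` differs from compound 2 in one place: 3,4-dichlorophenyl in place of 4-fluorophenyl on a saturated ring carbon. Among the compounds with values here, no measured pair makes this exact swap. The nearest guides are the change of a fluoro to a trifluoromethyl, seen in reverse in a 1.7-fold higher number from compound 1 to compound 2 (0.23 log units; within the scatter), and the addition of a second fluoro in a 1.3-fold higher number from compound 2 to compound 3 (0.11 log units; within the scatter); neither moved the number beyond the scatter, and the widest span on this core, a 2.2-fold higher number from compound 1 to compound 3 (0.34 log units; beyond the scatter), is only modest. A small shift toward a lower number is therefore the most that is expected, and none beyond the scatter would not surprise.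

Compound 4 is expected to give about 1300 nM, with a range from 500 nM to 3500 nM, meaning an estimated step of a 1.3-fold lower number from compound 2 to compound 4 (0.12 log units; within the scatter).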

Compound 4, half-maximal inhibitory concentration: 700 nM
Beside the measured number, compound 4's estimate is 1.9-fold (0.27 log units) above it; low and high end bracket the measured number.
By their numbers in this assay, from the lowest: compounds 4, 1, 2 and 3 (each within the scatter of the next, the first and the last beyond it).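

In this assay, the group on this saturated ring carbon now shows a single swap moving the number beyond the scatter: 3,4-dichlorophenyl in place of 4-fluorophenyl gives a 2.4-fold lower number from compound 2 to compound 4 (0.39 log units; beyond the scatter), and the same group in place of 2,4-difluorophenyl gives a 3.1-fold lower number from compound 3 to compound 4 (0.50 log units; beyond the scatter), both modest in size. Within the data shown here, the earlier swaps between compound 1, compound 2 and compound 3 showed only one such step, whereas 3,4-dichlorophenyl now stands clear of both fluorinated groups. It does not stand clear of 4-(trifluoromethyl)phenyl, since a 1.4-fold lower number from compound 1 to compound 4 (0.15 log units; within the scatter) stays within the scatter, so compound 1 and compound 4 cannot be ranked against each other, and the whole set spans only a modest range.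

No measurement available here explains why this swap changes the number. Still open, on these data alone, is what a single chlorine would do at this position, as in 4-chlorophenyl or 3-chlorophenyl, and how a phenyl ring carrying an amine or a carboxylic acid would compare with these four groups.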